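A few compounds are considered here, and "the series" means these few. Any claim that something is new, unique, unknown or untested is made for them only; others in the source may bear on it.

Compound 1 `Cc1ccc(S(=O)(=O)Nc2ccc(-c3ccccc3N3CCCC3)nn2)cc1`: 43.5 10^-6 cm/s
Compound 2 `COc1ccccc1-c1ccc(NS(=O)(=O)c2ccc(C)cc2)nn1`: 34.7 10^-6 cm/s

In an ADME assay for permeability, using PAMPA, at pH 7.4 (on this read-out lower numbers stand for lower permeability and higher numbers for higher permeability), compound 1 gives 43.5 10^-6 cm/s, and compound 2 lies within the usual scatter of it. Compound 3 `CN(C)c1cccc(S(=O)(=O)Nc2ccc(-c3ccccc3N3CCCC3)nn2)c1` keeps the core of compound 1 but carries 3-(dimethylamino)phenyl in place of 4-methylphenyl on a sulfonyl sulfur. For the measured compounds named here, no measured step changes the group at that place. The only one available, a 1.3-fold lower number from compound 1 to compound 2 (0.10 log units; within the scatter), puts methoxy in place of pyrrolidin-1-yl on an aromatic carbon, so it is a weak guide and stays within the scatter. The expected step is a 1.1-fold lower number from compound 1 to compound 3 (0.06 log units; within the scatter), which is none beyond the scatter. For compound 3 the estimate is 38 10^-6 cm/s, with an expected range of 13 10^-6 cm/s to 75 10^-6 cm/s.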

Compound 3, apparent permeability: 31.2 10^-6 cm/s
The estimate for compound 3 lay 1.2-fold (0.09 log units) above the measured number; measured number inside the range.
By their numbers in this assay, from the lowest: compounds 3, 2 and 1 (each within the scatter of the next).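

In this assay the sulfonyl sulfur now has a measured step of its own (a 1.4-fold lower number from compound 1 to compound 3 (0.14 log units; within the scatter)). The entering 3-(dimethylamino)phenyl carries a nitrogen and a hydrogen-bond acceptor that 4-methylphenyl lacks, yet this swap stays within the scatter, so the two groups cannot be told apart on this read-out. Nothing available explains this result. Still open, from the compounds shown here alone, is whether a group of another kind on the sulfonyl sulfur, such as a carboxylic acid or a short alkyl chain, would move the number beyond the scatter.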